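Placing a bromo group on compound 2

This account rests on a few compounds, and the source may have more. Where it says the series, first, only, none or still open, it means among the compounds named here.

In a functional assay on HeLa cells (Homo sapiens) for cytotoxicity, read by sulforhodamine B assay, with a stated time of 48 h (a lower number here means a stronger inhibitor, a higher number a weaker inhibitor), compound 2 `O=C(c1cccnc1)c1ccccc1O` gives 33000 nM. Among the measured compounds shown here, only one other compound here gives a number, and that is compound 3 `O=C(c1cccnc1)c1cc(Br)ccc1O` at 29000 nM. The step between them is a 1.1-fold lower number from compound 2 to compound 3 (0.06 log units; within the scatter), so this measurement cannot separate the two. Compound 1 `C=CCOc1cc(Br)ccc1C(=O)c1cccnc1` reaches only a limit in this assay, > 100000 nM. That value is a limit and not a number.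

Compound 4 `O=C(c1cccnc1)c1ccc(Br)cc1O` has not been measured yet. It is compound 2 with a single change: bromo in place of hydrogen on an aromatic carbon. The new bromo sits on an aromatic carbon, meta to a hydroxy group and para to a group of 8 heavy atoms. For the measured compounds named here, compound 3 carries its bromo on a different carbon of that ring, so the one measured step that bears on this change is the same kind of exchange made elsewhere: a 1.1-fold lower number from compound 2 to compound 3 (0.06 log units; within the scatter). A single step is thin evidence, but it offers no reason to expect a shift beyond the scatter in this assay, in either direction. The estimated step is a 1.1-fold lower number from compound 2 to compound 4 (0.06 log units; within the scatter). For compound 4 the expected value is 29000 nM, with an estimated range from 12000 nM to 70000 nM.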

Compound 4, half-maximal inhibitory concentration: 37000 nM
Estimate against measurement, compound 4: 1.3-fold (0.11 log units) below; low and high end bracket the measured number.
By their numbers in this assay, from the lowest: compounds 3, 2 and 4 (each within the scatter of the next). At a limit, above all of these: compound 1.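

With compound 4, bromo now sits on two different carbons of the ring that carries the hydroxy group, and in this assay neither change separates from compound 2: the new step is a 1.1-fold higher number from compound 2 to compound 4 (0.05 log units; within the scatter), and the earlier one is a 1.1-fold lower number from compound 2 to compound 3 (0.06 log units; within the scatter). So at this carbon, meta to a hydroxy group and para to a group of 8 heavy atoms, the exchange of hydrogen for bromo leaves the number within the scatter. Compound 4 also gives the first direct comparison with compound 1, which has the bromo on the same carbon and differs only by an allyl group on the oxygen, and this step is an at least 2.7-fold lower number from compound 1 to compound 4 (0.43 log units; beyond the scatter); its full size cannot be read, as compound 1 stands at a limit and not at a number: the limit of > 100000 nM in this assay, at which 1 of the 4 values shown sits.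

The compounds shown test only bromo on this ring, so it remains open whether an amine or a carboxylic acid on the same carbon would move the number beyond the scatter. They also leave open whether a methyl or a longer chain on the oxygen would behave like allyl or like hydrogen.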